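The source may hold more compounds than are shown below. What is called first, only, known or untested is meant among the compounds shown, and "the series" means these compounds.

Among the three stereoisomers measured in an assay on isolated protein for inhibition of cytosolic endo-beta-N-acetylglucosaminidase (Homo sapiens), tested at 1000 uM (on this read-out lower numbers stand for less inhibition and higher numbers for more inhibition at the one concentration tested (going by the name of the read-out)), compound 3 `O=C(O)[C@@H]1NC[C@@H](O)[C@@H](O)[C@H]1O` gives 26%, the highest number of the set, while compound 1 `O=C(O)[C@H]1NC[C@@H](O)[C@H](O)[C@H]1O` gives 6.3% and compound 2 `O=C(O)[C@H]1NC[C@H](O)[C@H](O)[C@H]1O` gives 7.6%. Compound 4 `O=C(O)[C@H]1NC[C@H](O)[C@@H](O)[C@H]1O` remains to be measured; (the two compounds have the same atoms and bonds and differ only in configuration as drawn: 2 of 4 stereo elements differ; a stereocentre at a saturated ring carbon is drawn R in compound 3 and S in compound 4; a stereocentre at a saturated ring carbon is drawn R in compound 3 and S in compound 4). Within the data shown here, the steps that bear on this are a number 19.7 percentage points higher from compound 1 to compound 3 (beyond the scatter) and a number 18.4 percentage points higher from compound 2 to compound 3 (beyond the scatter), both beyond the scatter, whereas a number 1.3 percentage points higher from compound 1 to compound 2 (within the scatter) stays within it; together they show that changing the drawn configuration at two or three ring carbons moved this assay modestly, while a single change did not (the fact that compounds 1 and 2 differ only in the configuration as drawn, (the fact that compounds 1 and 3 differ only in the configuration as drawn), (the fact that compounds 2 and 3 differ only in the configuration as drawn)). Compound 4 is therefore expected to give a lower number, closer to those of compound 1 and compound 2, a step of a number 16 percentage points lower from compound 3 to compound 4 (beyond the scatter). The estimate for compound 4 in this assay is 10%, with a range from 3% to 22%.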

Compound 4, a percentage reported as inhibition, at one concentration (the size of the read-out at that concentration, not a potency): 2.6%
The estimate for compound 4 lay 7.4 percentage points above the measured number, outside the stated range (below it).
By their numbers in this assay, from the lowest: compounds 4, 1 and 2 (each within the scatter of the next); then compound 3.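

In this assay, a number 23.4 percentage points lower from compound 3 to compound 4 (beyond the scatter) shows that changing the drawn configuration at two ring carbons is enough to remove the edge of compound 3, with no atom or bond altered: the fact that compounds 3 and 4 differ only in the configuration as drawn. The other two steps, a number 5 percentage points lower from compound 2 to compound 4 (within the scatter) and a number 3.7 percentage points lower from compound 1 to compound 4 (within the scatter), set no order among the remaining stereoisomers, so compound 3 alone stands apart. Still open, on these data alone, is which of those two ring carbons accounts for the step, and whether an amide or a hydroxymethyl group in place of the carboxylic acid would keep the number of compound 3.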